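The source may report more compounds than this note shows. Statements on the series, on what has been measured and on what is new or still open speak of the compounds shown alone.

Compound 1 `O=C1CC(c2ccc(Cl)cc2)Nc2c(Br)cc(Br)cc21` in a functional assay on MCF7 cells (Homo sapiens) for cytotoxicity, read by sulforhodamine B assay, with a stated time of 48 h (on this read-out lower numbers stand for higher toxicity in this test and higher numbers for lower toxicity in this test), gives > 100000 nM, which is a limit of the assay and not a number.
Compound 2 `O=C1CC(c2ccc(Br)cc2)Nc2c(Br)cc(Br)cc21` in this assay gives > 100000 nM, also a limit.
Compound 3 `N#Cc1ccc(C2CC(=O)c3cc(Br)cc(Br)c3N2)cc1` in this assay gives > 100000 nM, again a limit.

Compound 1 therefore stands nowhere definite on the scale: all three values sit at the limit of > 100000 nM in this assay, at which 3 of the 3 values shown sit. Compound 4 `CN(C)c1ccc(C2CC(=O)c3cc(Br)cc(Br)c3N2)cc1` differs from compound 1 by dimethylamino in place of chloro on an aromatic carbon. The steps at the same place, a step that the two limits leave unreadable from compound 1 to compound 2, a step that the two limits leave unreadable from compound 1 to compound 3 and a step that the two limits leave unreadable from compound 2 to compound 3, are all unreadable in size, so they give no direction for the new exchange. Compound 4 is consequently expected to show no step beyond the scatter, most likely another limit. Compound 4 is estimated at 150000 nM, with an expected range from 30000 nM to 1000000 nM. That estimate means an expected step that the limit leaves unreadable from compound 1 to compound 4.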

Compound 4, concentration lethal to 50% of the cells: > 100000 nM
Compound 4 ended at the assay's limit; the forecaster's own chance of this, stated with the estimate: 85%; the middle value is on the limit's open side.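

In this assay compound 4 gives > 100000 nM, a limit of the assay, so no step between it and compound 1, compound 2 or compound 3 can be read: the limit of > 100000 nM in this assay, at which 4 of the 4 values shown sit.

The compounds shown leave open whether chloro, bromo, cyano and dimethylamino differ at all in toxicity to these cells.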